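Propyl for Cyclohexyl at the Ring Nitrogen

The compounds below may be only part of what the source reports. "The series", "measured", "known", "first", "only" and "open" are said of these compounds alone.

Within the data shown here, compound 1 `Cc1cc(C(=O)O)nn1-c1ccc(S(=O)(=O)N2CCC(=O)N(C3CCCCC3)C2=S)cc1` stands at the low end of the three numbers measured so far: in a functional assay on the whole organism (blood, strain albino) with Mus musculus as the target, with stated times of 6 days and 3 h, at a dose of 1 mmol/kg by the oral route (a lower number here means less inhibition, a higher number more inhibition at the dose given (going by the name of the read-out)), compound 1 gives 2%. Compound 2 `Cc1cc(C)n(-c2ccc(S(=O)(=O)N3CCC(=O)N(C4CCCCC4)C3=S)cc2)n1` differs from it in one place, methyl in place of carboxy on an aromatic carbon, and gives 4%; the two values lie within the scatter of each other, a number 2 percentage points higher from compound 1 to compound 2 (within the scatter). Compound 3 `Cc1cc(C)n(-c2ccc(S(=O)(=O)N3CCC(=O)N(Cc4ccccc4)C3=S)cc2)n1` gives 18%, a separation from compound 1 that is beyond the scatter.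

Compound 4 `CCCN1C(=O)CCN(S(=O)(=O)c2ccc(-n3nc(C(=O)O)cc3C)cc2)C1=S` is compound 1 with one change: propyl in place of cyclohexyl on an amide-type nitrogen in a ring. Among the measured compounds shown here, the only measured step that touches this ring nitrogen is the one from compound 2 to compound 3, benzyl in place of cyclohexyl, which gave a number 14 percentage points higher from compound 2 to compound 3 (beyond the scatter). For the measured compounds named here, no measured compound carries a propyl group there, so the direction for this smaller chain is uncertain. Going by the values given here, because the one exchange at this position gave a number 14 percentage points higher from compound 2 to compound 3 (beyond the scatter), a rise of at most similar size, or none beyond the scatter, is expected for compound 4. Compound 4 is therefore estimated to give 8% in this assay, within 0% to 25%, an expected step of a number 6 percentage points higher from compound 1 to compound 4 (within the scatter).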

Compound 4, a percentage reported as inhibition, in the whole organism at one dose (the size of the read-out at that dose, not a potency): < 1%
Compound 4 was reported as a limit; the forecaster's own chance of this, stated with the estimate: 0%; middle value at least 7 percentage points from the limit.
By their numbers in this assay, from the lowest: compounds 1 and 2 (each within the scatter of the next); then compound 3. At a limit, below all of these: compound 4.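

Compound 4 gives < 1% in this assay, which is a limit of the assay and not a number. Exchanging the six-membered carbon ring of cyclohexyl for the open chain of propyl gives a number at least 1 percentage points lower from compound 1 to compound 4 (that floor lies within the scatter), so on this carboxy-bearing compound the smaller chain brings no rise, and a change at this ring nitrogen does not by itself lift the number. Any further gap cannot be read, because compound 4 stands at a limit: the limit of < 1% in this assay, at which 1 of the 4 values shown sits.

Still open, as far as these compounds go, is whether propyl would act alike with methyl in place of carboxy, the setting of the one rise seen at this nitrogen: a number 14 percentage points higher from compound 2 to compound 3 (beyond the scatter). Also open, from the compounds shown here alone, is what a longer chain such as hexyl, or a chain ending in an amine, would give at this ring nitrogen.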